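Trifluorophenyl in place of fluorophenyl: stability expectation

The compounds below may be only part of what the source reports. "The series", "measured", "known", "first", "only" and "open" are said of these compounds alone.

Measured compounds and their values:
Compound 1, `CS(=O)(=O)Nc1ccc2c(c1)S(=O)(=O)N=C(C1=C(O)[C@@H]3[C@H]4CC[C@H](C4)[C@@H]3N(Cc3ccccc3)C1=O)N2` — in an in vitro ADME assay on microsomes from liver (Homo sapiens) for metabolic stability, tested at 1 uM (a higher number here means that the compound lasts longer, a lower number that the compound disappears faster), compound 1 gives > 1 h, a limit of the assay.
Compound 2, `CS(=O)(=O)Nc1ccc2c(c1)S(=O)(=O)N=C(C1=C(O)[C@@H]3[C@H]4CC[C@H](C4)[C@@H]3N(Cc3ccccc3F)C1=O)N2` — in this assay compound 2 gives > 1 h, a limit of the assay.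
Compound 3, `Cc1ccc(CN2C(=O)C(C3=NS(=O)(=O)c4cc(NS(C)(=O)=O)ccc4N3)=C(O)[C@@H]3[C@H]4CC[C@H](C4)[C@@H]32)cc1F` — in this assay compound 3 gives > 1 h, a limit of the assay.

Compound 2 therefore stands at the limit of the assay, and the other two values shown sit at the same limit. The unmeasured compound 4 is `CS(=O)(=O)Nc1ccc2c(c1)S(=O)(=O)N=C(C1=C(O)[C@@H]3[C@H]4CC[C@H](C4)[C@@H]3N(Cc3ccc(F)c(F)c3F)C1=O)N2`. It differs from compound 2 as follows: 2,3,4-trifluorophenyl in place of 2-fluorophenyl on a saturated chain carbon bound to an amide-type nitrogen in a ring.

Among the compounds with values here, two measured steps touch the same part of the molecule. The first, a step that the two limits leave unreadable from compound 1 to compound 2, swaps in one fluorine on the aromatic ring; the second, a step that the two limits leave unreadable from compound 2 to compound 3, exchanges the whole ring substituent. Neither step can be read, because the limit of > 1 h in this assay, at which 3 of the 3 values shown sit, puts every value at the same limit. Within the data shown here, no measured step therefore gives a size or a direction for the change to compound 4, and the only available expectation is that compound 4 will also reach the limit.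

Compound 4 is expected to give 1.5 h in this assay, with a range from 0.8 h to 3 h. The step this estimate means, a step that the limit leaves unreadable from compound 2 to compound 4, is expected to be no change beyond the scatter.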

Compound 4, half-life: > 1 h
Compound 4 gave a limit, no number; the forecaster's own chance of this, stated with the estimate: 80%; the middle value lies beyond the limit too.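

Within the data shown here, no step to compound 4 from compound 1, compound 2 or compound 3 can be read, because all four compounds end at the same limit rather than at a number: the limit of > 1 h in this assay, at which 4 of the 4 values shown sit. On these data alone, how long each compound actually lasts in this assay stays open, and so does whether the 2,3,4-trifluorophenyl group changes that time at all.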